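The source may report more compounds than this note shows. Statements on the series, on what has been measured and on what is new or still open speak of the compounds shown alone.

Of the compounds shown here, three have been tested in an assay on HEK293 cells for agonist activity at Toll-like receptor 8 (Homo sapiens), read by reporter gene assay (on this read-out higher numbers stand for an effect only at larger amounts of compound and lower numbers for an effect already at smaller amounts), so far. Compound 1 `CCCCC1(O)C(N)=Nc2ccccc21` gives "not active" (no number reported) in this assay. Within the data shown here, compound 2 `CCCCCn1c(N)nc2c(OC)cccc21`, which carries a methoxy group on its shared core, gives 3740 nM in this assay, the only number obtained in this set. Compound 3 `CCCCCn1c(N)nc2c(Cl)cccc21`, with a chloro group in that place instead, gives "not active" (no number reported) in this assay.

Among the measured compounds shown here, compound 3 therefore stands without a number of its own, and it is one of two compounds in this group for which only the statement "not active" is available; the single measured value belongs to compound 2.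

Compound 4 `CCCCCn1c(N)nc2c(CC)cccc21` is the next compound to be measured in this assay. The change from compound 3 to compound 4 is ethyl in place of chloro on an aromatic carbon. For the measured compounds named here, no step between two measured compounds of this kind exists, so the size and direction of the move from compound 3 to compound 4 cannot be read from data; the only anchor is that compound 2 with a methoxy group gives a measurable but high value, while compound 3 with a chloro group gives none.

On that basis compound 4 is expected to give 8000 nM in this assay, with a range from 2000 nM to 40000 nM, and a real chance that no number is obtained.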

Compound 4, half-maximal effective concentration: 1650 nM
Beside the measured number, compound 4's estimate is 4.8-fold (0.69 log units) above it; the measured number lies below the stated range.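

In this assay, among these compounds, methoxy is no longer the only group on this aromatic carbon that gives a number: ethyl in its place gives a 2.3-fold lower number from compound 2 to compound 4 (0.36 log units; beyond the scatter), a modest gain that shows a measurable effect here does not depend on methoxy. Compound 3 gives "not active" (no number reported) and compound 4 gives 1650 nM, so changing this one group from chloro to ethyl separates a compound without a number from one with a number, even though neither group counts any hydrogen-bond donor or acceptor. No measurement shown here explains why these groups differ.

On these data alone, it remains open whether a longer chain such as propyl, or an amine on the same aromatic carbon, would lower the number further or lose it altogether. As far as these compounds go, it is also open whether the order of ethyl and methoxy would hold with a different chain on the shared core.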